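The compounds below may be only part of what the source reports. "The series", "measured", "known", "first", "only" and "open" are said of these compounds alone.

Working notes on the series, all values from a functional assay on MCF7 cells (Homo sapiens) for cytotoxicity, read by MTT assay, with a stated time of 72 h; a lower number here means a stronger inhibitor, a higher number a weaker inhibitor.

Compound 1 `CCOC(=O)c1c(C)oc2ncnc(Nc3cccc(C)c3)c12` returns only a limit of the assay in this assay: > 1000000 nM, the line the limit of > 1000000 nM in this assay, at which 1 of the 3 values shown sits, being where its value sits. Compound 2 `CCOC(=O)c1c(C)oc2ncnc(Nc3ccccc3)c12` gives 851000 nM in this assay. The change from compound 1 to compound 2 is hydrogen in place of methyl on an aromatic carbon and its step is an at least 1.1-fold lower number from compound 1 to compound 2 (0.07 log units; that floor lies within the scatter), a small move that cannot be separated from scatter. Compound 3 `Cc1cccc(Nc2ncnc3oc(C)c(C(=O)O)c23)c1` gives 57500 nM in this assay, the lowest number among the measured pair that report a number. The cores of compound 1 and compound 3 differ by hydrogen in place of ethyl on an oxygen next to a carbonyl group, with the step of an at least 17-fold lower number from compound 1 to compound 3 (1.24 log units; beyond the scatter).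

Compound 4 `Cc1oc2ncnc(Nc3ccccc3)c2c1C(=O)O` is not yet measured in this assay. It differs from compound 3 by hydrogen in place of methyl on an aromatic carbon, the same change as that from compound 1 to compound 2, at the same place. On that single measured step, which stays within scatter, compound 4 is expected to land close to compound 3: the expected step is a 1.3-fold lower number from compound 3 to compound 4 (0.11 log units; within the scatter). The estimate for compound 4 in this assay is therefore 45000 nM, with a range of 15000 nM to 150000 nM.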

Compound 4, half-maximal inhibitory concentration: 246000 nM
Beside the measured number, compound 4's estimate is 5.5-fold (0.74 log units) below it, and the stated range ends below it.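

On the core of compound 3, 3-methylphenyl to phenyl gives a 4.3-fold higher number from compound 3 to compound 4 (0.63 log units; beyond the scatter), and this does not match the same change on the core of compound 1: the same change on two cores in this assay, an at least 1.1-fold lower number (0.07 log units; that floor lies within the scatter) from compound 1 to compound 2 and a 4.3-fold higher number (0.63 log units; beyond the scatter) from compound 3 to compound 4, at least 5.0-fold (0.70 log units) apart, beyond the scatter of two such steps

Hydrogen in place of ethyl on the oxygen next to the carbonyl group gives a 3.5-fold lower number from compound 2 to compound 4 (0.54 log units; beyond the scatter), and this too differs in size from the same change made on the 3-methylphenyl compounds: the same change on two cores in this assay, an at least 17-fold lower number (1.24 log units; beyond the scatter) from compound 1 to compound 3 and a 3.5-fold lower number (0.54 log units; beyond the scatter) from compound 2 to compound 4, at least 5.0-fold (0.70 log units) apart, beyond the scatter of two such steps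

Within the data shown here, compound 1 stands at > 1000000 nM, a limit of the assay and not a number, so both gaps are floors whose full size is unknown, and two pairs of steps show only that neither change can be carried unaltered between these cores, not how either would behave on any other core.

The compounds shown leave open whether a chlorine or a methoxy group in place of the methyl on the aromatic ring would follow the step seen on either core. They also leave open how an amide or a longer chain in place of the ethyl ester would read in this assay.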